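Estimating compound 3 from one measured step

This account rests on a few compounds, and the source may have more. Where it says the series, first, only, none or still open, it means among the compounds named here.

Measured in an ADME assay on MT4 cells (Homo sapiens) for inhibition, read by MTT assay, with a stated time of 5 days; on this read-out lower numbers stand for higher toxicity in this test and higher numbers for lower toxicity in this test:
- Compound 1 `Cc1cc(C)c(Oc2cc(Nc3ccc(C#N)cc3)ncc2[N+](=O)[O-])c(C)c1`: 69900 nM
- Compound 2 `Cc1cc(Cl)cc(C)c1Oc1cc(Nc2ccc(C#N)cc2)ncc1[N+](=O)[O-]`: 11100 nM

Of these two compounds, compound 2 has the lower number in this assay, and the gap to compound 1 lies beyond the scatter. Compound 3 `N#Cc1ccc(Nc2cc(Oc3c(Cl)cccc3Cl)c([N+](=O)[O-])cn2)cc1` has not yet been measured. It carries 2,6-dichlorophenyl in place of 4-chloro-2,6-dimethylphenyl on an oxygen on an aromatic ring.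

Among the measured compounds shown here, only one measured step bears on this change: a 6.3-fold lower number from compound 1 to compound 2 (0.80 log units; beyond the scatter), a modest step with chloro in place of methyl on an aromatic carbon. That step matches the change only in part, since here a different group leaves and enters as a whole. For the measured compounds named here, no measured step separates these parts, so the direction stays open and no step beyond the scatter is expected: a 1.2-fold higher number from compound 2 to compound 3 (0.07 log units; within the scatter). For compound 3 the estimated value is 13000 nM, with an expected range from 4500 nM to 38000 nM.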

Compound 3, half-maximal cytotoxic concentration: 27700 nM
Beside the measured number, compound 3's estimate is 2.1-fold (0.33 log units) below it; the measured number falls inside the stated range.
By their numbers in this assay, from the lowest: compound 2; then compound 3; then compound 1.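

In this assay, among the compounds shown here, the group on the oxygen can move the number upward as well as downward: 2,6-dichlorophenyl in place of 4-chloro-2,6-dimethylphenyl gives a 2.5-fold higher number from compound 2 to compound 3 (0.40 log units; beyond the scatter) while the one earlier step had gone down. In place of 2,4,6-trimethylphenyl, the same group gives a 2.5-fold lower number from compound 1 to compound 3 (0.40 log units; beyond the scatter) so compound 3 lies between the other two, and the two chlorine-bearing compounds do not sit at one level. No measurement shown accounts for these shifts.

The compounds shown leave open how much of the rise from compound 2 to compound 3 belongs to the lost 4-chloro group and how much to the methyl groups replaced by chlorine, as these changes occur together. They also leave open how the number would respond to a methoxy group or an amine on this phenyl ring.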